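From a Free Hydroxy to an Ester-Bearing Chain

The compounds below may be only part of what the source reports. "The series", "measured", "known", "first", "only" and "open" are said of these compounds alone.

Compound 1 `CCOC(=O)CCO/N=C(/c1ccc(OC)c(OC)c1OC)c1cccc2ccccc12` gives > 20000 nM in a functional assay on THP-1 cells (Homo sapiens) for inhibition, read by sulforhodamine B assay, with a stated time of 48 h (on this read-out higher numbers stand for weaker inhibition and lower numbers for stronger inhibition), which is a limit of the assay.
Compound 2 `COc1ccc(/C(=N/O)c2cccc3ccccc23)c(OC)c1OC` gives > 20000 nM in this assay, which is again a limit of the assay.

Compound 2 therefore stands at the limit only; both values shown sit there, as the limit of > 20000 nM in this assay, at which 2 of the 2 values shown sit, records. Going by the values given here, the only measured step, a step that the two limits leave unreadable from compound 1 to compound 2, is accordingly not readable in size or direction, since both ends are limits. Compound 3 `CCOC(=O)CO/N=C(/c1ccc(OC)c(OC)c1OC)c1cccc2ccccc12` carries the change ((ethoxycarbonyl)methyl in place of hydrogen on an oxygen), a shorter analogue of the chain that compound 1 bears on the same oxygen. Among the compounds with values here, no measured step gives a readable size to guide this change, so no movement beyond the scatter is expected, and compound 3 is expected most likely to return a limit as well. Compound 3 is estimated at 30000 nM, within 10000 nM to 100000 nM, which means an expected step that the limit leaves unreadable from compound 2 to compound 3.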

Compound 3, half-maximal inhibitory concentration: > 20000 nM
Compound 3: a limit, no number (the forecaster's own chance of this, stated with the estimate: 85%); the middle value does not contradict the limit.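

In this assay compound 3 gives > 20000 nM as a limit of the assay. Going by these compounds alone, no step among compound 1, compound 2 and compound 3 can be read: the limit of > 20000 nM in this assay, at which 3 of the 3 values shown sit. Going by these compounds, how these three compounds rank against one another remains open, as does whether any group on this oxygen gives a measurable value.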